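The compounds below may be only part of what the source reports. "The series", "measured", "known", "first", "only" and "open" are said of these compounds alone.

Measured so far:
- compound 1 `CCCC(=O)C1=C(C)NC(=O)NC1c1ccco1`: 1%
- compound 2 `CC1=C(C(=O)C2CC2)C(c2ccoc2)NC(=O)N1`: 16%

In an assay on membranes from HeLa cells for displacement of a labelled ligand from adenosine receptor A3 (Homo sapiens), read by scintillation counting, with a stated time of 180 min, tested at 1 uM (a higher number here means more inhibition at the concentration tested (going by the name of the read-out), a lower number less inhibition), compound 2 gives 16%, the higher of the two numbers, and compound 1 gives 1%, which lies beyond the scatter below it. Among the compounds with values here, compound 1 and compound 2 differ in more than one place, so the two values show only that the pair sits apart; no single change can be read from them.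

Compound 3 `CCCC(=O)C1=C(C)NC(=O)NC1c1ccoc1` is not yet measured in this assay. It differs from compound 2 in one place: propyl in place of cyclopropyl on a carbonyl carbon, on a carbonyl carbon whose other neighbours are a double-bonded ring carbon. Within the data shown here, no measured pair isolates this change. Compound 1 carries the same propyl ketone and gives 1%, but its other difference from compound 2 leaves the effect of the ketone change open. A step of a number 8 percentage points lower from compound 2 to compound 3 (within the scatter) is expected, a small decrease that may well stay within the scatter. Compound 3 is estimated at 8%, with a range from 0% to 22%.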

Compound 3, a percentage reported as inhibition, at one concentration (the size of the read-out at that concentration, not a potency): 2%
Estimate against measurement, compound 3: 6 percentage points above; measured number inside the range.
By their numbers in this assay, from the lowest: compounds 1 and 3 (each within the scatter of the next); then compound 2.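

In this assay, the change of propyl in place of cyclopropyl on a carbonyl carbon is now isolated: it gives a number 14 percentage points lower from compound 2 to compound 3 (beyond the scatter), so at this position the two groups can be told apart, with cyclopropyl on the side of the higher number. Furan-3-yl in place of furan-2-yl on a saturated ring carbon, read with the propyl ketone kept fixed, gives a number 1 percentage points higher from compound 1 to compound 3 (within the scatter), so the two furan attachments cannot be told apart in this setting. No measurement offered here gives a reason for the ketone step.

On these data alone, whether the cyclopropyl step also holds with furan-2-yl on the saturated ring carbon remains open. So does the outcome for other groups on the carbonyl carbon, such as a butyl chain or a phenyl ring.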